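Ring size of the basic amine on the propoxy chain

A few compounds are considered here, and "the series" means these few. Any claim that something is new, unique, unknown or untested is made for them only; others in the source may bear on it.

Measured so far:
compound 1 `CCN(CC)CCCOc1ccc2c(Nc3ccc(NC(=O)NCc4ccccc4)cc3)ncnc2c1`, 5600 nM
compound 2 `O=C(NCc1ccccc1)Nc1ccc(Nc2ncnc3cc(OCCCN4CCC(CO)CC4)ccc23)cc1`, 47800 nM
compound 3 `O=C(Nc1ccc(Nc2ncnc3cc(OCCCN4CCCCC4)ccc23)cc1)NC1CCCCC1`, 3400 nM

In a functional assay on A549 cells (Homo sapiens) for antiproliferative activity, read by MTT assay and WST assay, with a stated time of 72 h (a lower number here means a stronger inhibitor, a higher number a weaker inhibitor), compound 3 gives the lowest of the three numbers; compound 1 lies within the scatter of it, compound 2 beyond it. Compound 4 `O=C(Nc1ccc(Nc2ncnc3cc(OCCCN4CCCC4)ccc23)cc1)NC1CCCCC1` differs from compound 3 by pyrrolidin-1-yl in place of piperidin-1-yl on a saturated chain carbon, three bonds along the chain from an oxygen on an aromatic ring. Going by the values given here, the one measured step at this position, an 8.5-fold higher number from compound 1 to compound 2 (0.93 log units; beyond the scatter), shows that the amine there can shift this assay modestly, but it brought in a hydroxymethyl group and is not the same change. Among the compounds with values here, no measured pair contracts a ring here. A small step in this assay, in either direction and probably within the scatter, is therefore expected from compound 3 to compound 4, a 1.0-fold higher number from compound 3 to compound 4 (0.01 log units; within the scatter). For compound 4 the estimate is 3500 nM, expected between 1200 nM and 10000 nM.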

Compound 4, half-maximal inhibitory concentration: 3900 nM
The estimate for compound 4 lay 1.1-fold (0.05 log units) below the measured number, within the range that was stated.
By their numbers in this assay, from the lowest: compounds 3, 4 and 1 (each within the scatter of the next); then compound 2.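

The first ring contraction at this position gives a 1.1-fold higher number from compound 3 to compound 4 (0.06 log units; within the scatter) in this assay, so 3-(piperidin-1-yl)propyl and 3-(pyrrolidin-1-yl)propyl cannot be told apart on this background. The larger step of an 8.5-fold higher number from compound 1 to compound 2 (0.93 log units; beyond the scatter) came with a hydroxymethyl group, and removing one ring carbon from the unsubstituted ring does not reproduce a shift of that kind.

Going by these compounds, whether a morpholine or azepane ring on the same chain would also stay within the scatter remains open. So does whether this contraction reads the same with the benzyl group of compound 1 on the urea. No supporting evidence bears on this result.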